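This account rests on a few compounds, and the source may have more. Where it says the series, first, only, none or still open, it means among the compounds named here.

Compound 3 `Cc1ccc(S(=O)(=O)c2cnc3ccc(Cl)cc3c2N2CCC(C)CC2)cc1Cl` sits lowest of the three measured numbers in an assay on isolated protein for displacement of a labelled ligand from metabotropic glutamate receptor 5 (Homo sapiens), with a stated time of 60 min, tested at 1 uM (on this read-out higher numbers stand for more inhibition at the one concentration tested (going by the name of the read-out) and lower numbers for less inhibition), and gives 81%; compound 1 `CC1CCN(c2c(S(=O)(=O)c3ccc(Cl)cc3)cnc3ccc(Cl)cc23)CC1` gives 92% and compound 2 `COc1ccc(S(=O)(=O)c2cnc3ccc(C)cc3c2N2CCC(C)CC2)cc1Cl` gives 93%. Among the measured compounds shown here, the only measured step that reaches compound 3, a number 11 percentage points lower from compound 1 to compound 3 (beyond the scatter), was a modest fall on exchanging the aryl group on the sulfonyl sulfur. Compound 4 `COc1ccc(S(=O)(=O)c2cnc3ccc(Cl)cc3c2N2CCC(C)CC2)cc1Cl` differs from compound 3 by methoxy in place of methyl on an aromatic carbon. For the measured compounds named here, no measured step covers this exchange. Compound 2, which carries the same 3-chloro-4-methoxyphenyl group on a core bearing methyl where compound 4 bears chloro, lies high, as does compound 1. For compound 4 a small rise back toward those numbers is therefore expected, a number 7 percentage points higher from compound 3 to compound 4 (within the scatter). Compound 4 is estimated at 88%, between 77% and 97%.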

Compound 4, a percentage reported as inhibition, at one concentration (the size of the read-out at that concentration, not a potency): 46%
For compound 4 the middle estimate is 42 percentage points above the measured one; the measured number lies below the stated range.
By their numbers in this assay, from the lowest: compound 4; then compound 3; then compounds 1 and 2 (each within the scatter of the next).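

In this assay, methoxy in place of methyl on this aromatic carbon, ortho to a chloro group, is far from neutral, giving a number 35 percentage points lower from compound 3 to compound 4 (beyond the scatter). The 3-chloro-4-methoxyphenyl group does not carry a high number on every core: chloro in place of methyl on an aromatic carbon gives a number 47 percentage points lower from compound 2 to compound 4 (beyond the scatter), and 3-chloro-4-methoxyphenyl in place of 4-chlorophenyl on the sulfonyl sulfur gives a number 46 percentage points lower from compound 1 to compound 4 (beyond the scatter). Nothing measured here gives a cause for these falls.
Open, from the compounds shown here alone, is whether ethoxy or hydroxy at this carbon tracks methoxy or methyl. Also open, going by these compounds, is how 3-chloro-4-methylphenyl reads on the core of compound 2.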